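The source may hold more compounds than are shown below. What is called first, only, known or untested is meant among the compounds shown, and "the series" means these compounds.

Compound 1 `CCc1cc(C(C)=O)c(OC)cc1OCCCCCC(C)(C)c1nnn[nH]1` stands at the higher of the two numbers measured in an assay on isolated protein for antagonist activity at Bile acid receptor (Homo sapiens), read by HTRF, with a stated time of 30 min (a lower number here means a stronger inhibitor, a higher number a weaker inhibitor), where compound 1 gives 5500 nM. Its neighbour compound 2 `CCc1cc(C(C)=O)c(OC(C)c2ccccc2)cc1OCCCCCC(C)(C)c1nnn[nH]1` gives 1700 nM in this assay, and the step of a 3.2-fold lower number from compound 1 to compound 2 (0.51 log units; beyond the scatter) came from 1-phenylethyl in place of methyl on an oxygen on an aromatic ring. Compound 3 `CCc1cc(C(C)=O)c(OCC2CCCCC2)cc1OCCCCCC(C)(C)c1nnn[nH]1` also enlarges this methyl: cyclohexyl in place of hydrogen on a saturated chain carbon bound to an oxygen on an aromatic ring. Going by the values given here, only the step from compound 1 to compound 2 bears on this change, and by its measure a modest improvement is expected for compound 3, an estimated step of a 2.8-fold lower number from compound 1 to compound 3 (0.44 log units; beyond the scatter). Compound 3 is therefore estimated at 2000 nM, within 800 nM to 6000 nM.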

Compound 3, half-maximal inhibitory concentration: 2900 nM
Compound 3: middle estimate off by 1.5-fold (0.16 log units), on the low side; measured number inside the range.
By their numbers in this assay, from the lowest: compounds 2, 3 and 1 (each within the scatter of the next, the first and the last beyond it).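

Unlike 1-phenylethyl, cyclohexylmethyl on this oxygen gives no step beyond the scatter from the methoxy of compound 1 in this assay (a 1.9-fold lower number from compound 1 to compound 3 (0.28 log units; within the scatter)). The two large groups also cannot be told apart (a 1.7-fold higher number from compound 2 to compound 3 (0.23 log units; within the scatter)), so a saturated ring and an aromatic one are not separated here. No evidence is given that accounts for these numbers.

Going by these compounds, how an amine or a carboxylic acid on this oxygen would read remains open. So does a longer chain carrying the cyclohexyl ring.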